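Swapping 2-carboxycyclopropyl for an open 1-(carboxymethyl)ethyl group

A few compounds are considered here, and "the series" means these few. Any claim that something is new, unique, unknown or untested is made for them only; others in the source may bear on it.

Of the compounds shown here, two have numbers so far in an in vivo ADME assay on the whole organism (strain Sprague-Dawley) for metabolic stability, with Rattus norvegicus as the target (on this read-out higher numbers stand for a longer-lived compound and lower numbers for a shorter-lived compound), and they lie well apart. Compound 1 (`Cc1cc(CCC(=O)O)ccc1-c1noc(-c2ccc(OC(C)C)c(C#N)c2)n1`) gives 0.7 h in this assay and sits at the low end. Compound 2 (`Cc1cc([C@@H]2C[C@H]2C(=O)O)ccc1-c1noc(-c2ccc(OC(C)C)c(C(F)(F)F)c2)n1`) gives 6.3 h in the same measurement and is the higher of the two, with a gap to compound 1 that lies beyond the scatter.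

Compound 3 (`Cc1cc(C(C)CC(=O)O)ccc1-c1noc(-c2ccc(OC(C)C)c(C(F)(F)F)c2)n1`) keeps the core of compound 2 but carries 1-(carboxymethyl)ethyl in place of 2-carboxycyclopropyl on an aromatic carbon, and it has yet to be measured. Going by the values given here, no measured pair isolates this exchange, so the data offer no direct guide to its size. Among the compounds with values here, compound 1 at 0.7 h shows only that much shorter values occur in this small set, which makes a fall the more cautious expectation. In this assay a modest fall is expected, estimated as a 2.1-fold lower number from compound 2 to compound 3 (0.32 log units; beyond the scatter) and close to the edge of the scatter. For compound 3 the expected value is 3 h with an estimated range from 1.2 h to 7.5 h in this measurement.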

Compound 3, half-life: 3.1 h
The estimate for compound 3 lay 1.0-fold (0.01 log units) below the measured number; the measured number falls inside the stated range.
By their numbers in this assay, from the lowest: compound 1; then compound 3; then compound 2.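

In this assay, going by these compounds alone, this exchange gives a 2.0-fold lower number from compound 2 to compound 3 (0.31 log units; beyond the scatter), and it is the first step in the set that isolates a single change at this position, on an aromatic carbon para to a large group and meta to a methyl group. The step shows that replacing the three-membered ring of 2-carboxycyclopropyl with the ring-free 1-(carboxymethyl)ethyl, which has the same number of heavy atoms, shifts the half-life by a modest amount that still lies beyond the scatter, so the two groups are not interchangeable on this read-out. Nothing measured here bears on what lies behind this shift.

On these data alone, whether the exchange would have a step of similar size in a compound carrying nitrile in place of trifluoromethyl remains open, as this single pair speaks only for the trifluoromethyl series. Also open, as far as these compounds go, is how a cyclobutane ring bearing the carboxylic acid, or a longer chain ending in that acid, would compare at this position with 2-carboxycyclopropyl and 1-(carboxymethyl)ethyl.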